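The source may report more compounds than this note shows. Statements on the series, on what has been measured and on what is new or still open speak of the compounds shown alone.

Measured in a functional assay on KB cells (Homo sapiens) for cytotoxicity, read by resazurin assay, with a stated time of 3 days; on this read-out higher numbers stand for weaker inhibition and lower numbers for stronger inhibition:
- compound 1 `CCCCCCC(=O)NCC(C)(C)CC1=C(O)C(=O)c2ccccc2C1=O`: 28200 nM
- compound 2 `CCCCCCCCCCC(=O)NCC(C)(C)CC1=C(O)C(=O)c2ccccc2C1=O`: 17600 nM
- compound 3 `CCCCCCCCCCCCCCCC(=O)NCC(C)(C)CC1=C(O)C(=O)c2ccccc2C1=O`: 5120 nM

Compound 1 stands at the upper end of this range: the data show a 1.6-fold lower number from compound 1 to compound 2 (0.20 log units; within the scatter), and a 5.5-fold lower number from compound 1 to compound 3 (0.74 log units; beyond the scatter). The next compound, compound 4 `CCCCCCC(=O)OCC(C)(C)CC1=C(O)C(=O)c2ccccc2C1=O`, departs from it by (hexylcarbonyl)oxy in place of (hexylcarbonyl)amino on a saturated chain carbon, three bonds along the chain from a double-bonded ring carbon, on a saturated chain carbon, three bonds along the chain from a double-bonded ring carbon. Among the compounds with values here, no measured step touches this exchange. All of them alter only the chain, so a 5.5-fold lower number from compound 1 to compound 3 (0.74 log units; beyond the scatter) and a 3.4-fold lower number from compound 2 to compound 3 (0.54 log units; beyond the scatter) offer a scale and no direction. No change beyond the scatter is therefore expected in this assay. The expected step is a 1.1-fold lower number from compound 1 to compound 4 (0.05 log units; within the scatter). For compound 4 the estimated value is 25000 nM, with an expected range from 8000 nM to 70000 nM.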

Compound 4, half-maximal inhibitory concentration: 14400 nM
Beside the measured number, compound 4's estimate is 1.7-fold (0.24 log units) above it, within the range that was stated.
By their numbers in this assay, from the lowest: compound 3; then compounds 4, 2 and 1 (each within the scatter of the next).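

Within the data shown here, compound 4 gives the first reading at this position, since the earlier compounds altered only the chain: in this assay, (hexylcarbonyl)oxy in place of (hexylcarbonyl)amino gives a 2.0-fold lower number from compound 1 to compound 4 (0.29 log units; within the scatter). The amide hydrogen can therefore be lost here without a change beyond the scatter on this read-out. Nothing measured here offers an explanation for this result.

The compounds shown leave open whether the same exchange would read alike with the decyl-length or pentadecyl-length acyl chains of compound 2 and compound 3. They also leave open how a carbamate or a plain amine would read on the same saturated chain carbon.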